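This account rests on a few compounds, and the source may have more. Where it says the series, first, only, none or still open, it means among the compounds named here.

Within the data shown here, in a functional assay on A549 cells (Homo sapiens) for cytotoxicity, read by MTT assay, with a stated time of 48 h (on this read-out lower numbers stand for stronger inhibition and higher numbers for weaker inhibition), compound 2 `CC(C)=CCC/C(C)=C/CC/C(C)=C/CC[C@@H]1[C@@]2(C)C/C(=C\c3ccc(OCc4cn(-c5cccc([N+](=O)[O-])c5)nn4)cc3)C(=O)C(C)(C)[C@@H]2CC[C@@]1(C)O` gives 126000 nM, the higher of the two numbers measured so far, though its only neighbour, compound 1 `CC(C)=CCC/C(C)=C/CC/C(C)=C/CC[C@@H]1[C@@]2(C)C/C(=C\c3ccc(OCc4cn(-c5ccccc5)nn4)cc3)C(=O)C(C)(C)[C@@H]2CC[C@@]1(C)O` at 100000 nM, sits within the scatter of it. Compound 3 `CC(C)=CCC/C(C)=C/CC/C(C)=C/CC[C@@H]1[C@@]2(C)C/C(=C\c3ccc(OCc4cn(-c5ccncc5)nn4)cc3)C(=O)C(C)(C)[C@@H]2CC[C@@]1(C)O` differs from compound 2 by pyridin-4-yl in place of 3-nitrophenyl on an aromatic nitrogen. Among the measured compounds shown here, the one measured step, a 1.3-fold higher number from compound 1 to compound 2 (0.10 log units; within the scatter), altered the same outer group and stayed within the scatter, so in this assay no step beyond the scatter is expected from this change either. Compound 3 is therefore estimated at 110000 nM, with a range from 50000 nM to 250000 nM. The expected step is a 1.1-fold lower number from compound 2 to compound 3 (0.06 log units; within the scatter).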

Compound 3, half-maximal inhibitory concentration: 34000 nM
Compound 3: middle estimate off by 3.2-fold (0.51 log units), on the high side; measured number below the stated range.
By their numbers in this assay, from the lowest: compound 3; then compounds 1 and 2 (each within the scatter of the next).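

The outer group on the aromatic nitrogen of the five-membered ring can move the number in this assay beyond the scatter: pyridin-4-yl gives a 3.7-fold lower number from compound 2 to compound 3 (0.57 log units; beyond the scatter), and a 2.9-fold lower number from compound 1 to compound 3 (0.47 log units; beyond the scatter). Among these compounds, replacing the carbon-only ring with a ring holding a hetero atom therefore did what adding nitro to the phenyl ring did not. Nothing available explains this difference. Still open, on these data alone, is whether the number falls further with a pyrimidine ring at this position. A phenyl ring carrying an amine is equally untested here.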